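Shifting a Methyl Group Around a Thiophene Ring

The source may report more compounds than this note shows. Statements on the series, on what has been measured and on what is new or still open speak of the compounds shown alone.

In a functional assay on Hep 3B2 cells (Homo sapiens) for cytotoxicity, read by MTT assay (a higher number here means a weaker inhibitor, a lower number a stronger inhibitor), compound 1 (`COc1ccc(OC)c(C(=O)/C=C/c2ccco2)c1`) gives 19000 nM and compound 2 (`COc1ccc(OC)c(C(=O)/C=C/c2ccsc2)c1`) gives 5700 nM while compound 3 (`COc1ccc(OC)c(C(=O)/C=C/c2ccc(C)s2)c1`) gives 3400 nM as its reading. Compound 3 sits level with compound 2 and clearly under compound 1. In compound 4 (`COc1ccc(OC)c(C(=O)/C=C/c2sccc2C)c1`) 3-methylthiophen-2-yl takes the place of 5-methylthiophen-2-yl on a double-bonded chain carbon bound to a double-bonded chain carbon (3-methylthiophen-2-yl in place of 5-methylthiophen-2-yl on a double-bonded chain carbon bound to a double-bonded chain carbon). Among the measured compounds shown here, the closest precedent, a swap between two thiophene groups, stayed small (a 1.7-fold lower number from compound 2 to compound 3 (0.22 log units; within the scatter)). Leaving furan-2-yl gave modest steps (a 3.3-fold lower number from compound 1 to compound 2 (0.52 log units; beyond the scatter) and a 5.6-fold lower number from compound 1 to compound 3 (0.75 log units; beyond the scatter)). No step beyond the scatter is therefore expected in this assay here (a 1.1-fold higher number from compound 3 to compound 4 (0.05 log units; within the scatter)). For compound 4 the estimate is 3800 nM with an expected range of 1600 nM to 9000 nM in this measurement.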

Compound 4, half-maximal inhibitory concentration: 16700 nM
Estimate against measurement, compound 4: 4.4-fold (0.64 log units) below; measured number above the stated range.
By their numbers in this assay, from the lowest: compounds 3 and 2 (each within the scatter of the next); then compounds 4 and 1 (each within the scatter of the next).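

Where the methyl group sits on the thiophene matters at this place: in this assay, the same atoms joined differently give (a 4.9-fold higher number from compound 3 to compound 4 (0.69 log units; beyond the scatter)). The 3-methylthiophen-2-yl group also stands apart from thiophen-3-yl (a 2.9-fold higher number from compound 2 to compound 4 (0.47 log units; beyond the scatter)) but not from furan-2-yl (a 1.1-fold lower number from compound 1 to compound 4 (0.06 log units; within the scatter)), so the lower numbers seen on leaving furan-2-yl do not hold for every thiophene group shown. Nothing measured here explains this difference.

On these data alone, what plain thiophen-2-yl would give at this place stays open, and with it whether each methyl group raises or lowers the number. As far as these compounds go, how an amine on the thiophene would behave is equally open.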